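A few compounds are considered here, and "the series" means these few. Any claim that something is new, unique, unknown or untested is made for them only; others in the source may bear on it.

Working notes on the series. All three measured members share one core and an amide-linked chain; they are compared in an assay on isolated protein for inhibition of protein deacetylase HDAC6 (Homo sapiens), read by fluorescence; on this read-out higher numbers stand for weaker inhibition and lower numbers for stronger inhibition. Compound 1 `Cn1cc(-c2ccccc2Oc2ccccc2)c2cc(C(=O)NCCCCCCC(=O)NO)[nH]c2c1=O` gives 4.7 nM. Compound 3 `Cn1cc(-c2ccccc2Oc2ccccc2)c2cc(C(=O)NCCCCC(=O)NO)[nH]c2c1=O` gives 4 nM. Compound 2 `Cn1cc(-c2ccccc2Oc2ccccc2)c2cc(C(=O)NCCCCC(=O)Nc3ccccc3N)[nH]c2c1=O` returns only > 500 nM, which is a limit of this assay and not a number. On the numbers shown, compound 3 stands at the lowest of the two, with compound 1 nearest; the step of a 1.2-fold lower number from compound 1 to compound 3 (0.07 log units; within the scatter) lies within the scatter, so no order between the two is claimed.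

Compound 4 `Cn1cc(-c2ccccc2Oc2ccccc2)c2cc(C(=O)NCCCCCCC(=O)Nc3ccccc3N)[nH]c2c1=O` is the next member, not yet measured. Its change from compound 3: 2-((2-aminophenyl)carbamoyl)ethyl in place of hydroxycarbamoyl on a saturated chain carbon, four bonds along the chain from an amide-type nitrogen. Two kinds of measured step bear on it. The chain length by itself, a 1.2-fold lower number from compound 1 to compound 3 (0.07 log units; within the scatter), was within the scatter. The terminal group swap was large in both directions: an at least 120-fold lower number from compound 2 to compound 3 (2.09 log units; beyond the scatter) and an at least 100-fold higher number from compound 1 to compound 2 (2.02 log units; beyond the scatter), the latter ending at the limit of > 500 nM in this assay, at which 1 of the 3 values shown sits. Compound 4 pairs the longer chain of compound 1 with the 2-aminophenyl amide of compound 2, so a large rise in this assay is expected, a 500-fold higher number from compound 3 to compound 4 (2.70 log units; beyond the scatter), quite possibly reported only as a limit again. Compound 4 is estimated at 2000 nM, range 500 nM to 10000 nM.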

Compound 4, half-maximal inhibitory concentration: > 500 nM
Compound 4: a limit, no number; the forecaster's own chance of this, stated with the estimate: 75%; the middle value is on the limit's open side.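

In this assay, the exchange of hydroxy for 2-aminophenyl on the amide-type nitrogen now has a second chain length behind it, so the large loss is no longer tied to the chain of compound 2: the same change on two cores in this assay, an at least 120-fold lower number (2.09 log units; beyond the scatter) from compound 2 to compound 3 and an at least 100-fold lower number (2.02 log units; beyond the scatter) from compound 4 to compound 1; the limit leaves it open whether they differ On the longer chain, the 2-(2-aminophenyl)carbamoyl end stays well apart from both hydroxycarbamoyl compounds, with an at least 100-fold higher number from compound 1 to compound 4 (2.02 log units; beyond the scatter) and an at least 120-fold higher number from compound 3 to compound 4 (2.09 log units; beyond the scatter). Compound 4 rests on a limit and not a number, as compound 2 does, and the step between these two cannot be read: the limit of > 500 nM in this assay, at which 2 of the 4 values shown sit.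

From the compounds shown here alone, how far compound 2 and compound 4 lie past that limit remains open, and so does any effect of chain length among the 2-aminophenyl amides. Also open, going by these compounds, is whether a carboxylic acid or a primary amide at the chain end, or a shorter chain carrying hydroxycarbamoyl, would give values near those of compound 1 and compound 3 in this assay.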